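The source may report more compounds than this note shows. Statements on the series, on what has been measured and on what is new or still open speak of the compounds shown alone.

In an ADME assay on HepG2 cells (Homo sapiens) for cytotoxicity, read by luminescence, with a stated time of 72 h; on this read-out higher numbers stand for an effect only at larger amounts of compound and lower numbers for an effect already at smaller amounts:
- compound 1 `CCOC(=O)c1c(-c2cccc(Oc3ccccc3)c2)[nH]c2cc(OC)c(Cl)cc2c1=O`: > 21500 nM
- compound 2 `CCOC(=O)c1c(-c2cccc(Oc3ccccc3)c2)[nH]c2cc(OC)c(F)cc2c1=O`: > 21500 nM
- compound 3 `CCOC(=O)c1c(-c2cccc(F)c2)[nH]c2cc(OC)c(F)cc2c1=O`: > 21500 nM

All three entries are limits and not numbers: the limit of > 21500 nM in this assay, at which 3 of the 3 values shown sit. Compound 2 therefore has no exact position in the series, and its entry of > 21500 nM is a limit.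

Compound 4 `COc1cc2[nH]c(-c3cccc(Oc4ccccc4)c3)c(C(=O)NCCCN3CCCC3)c(=O)c2cc1F` differs from compound 2 at one place: (3-(pyrrolidin-1-yl)propyl)amino in place of ethoxy on a carbonyl carbon. In words, this is (3-(pyrrolidin-1-yl)propyl)amino in place of ethoxy on a carbonyl carbon.

For the measured compounds named here, two measured steps touch compound 2: a step that the two limits leave unreadable from compound 1 to compound 2, with fluoro in place of chloro on an aromatic carbon, and a step that the two limits leave unreadable from compound 2 to compound 3, with fluoro in place of phenoxy on an aromatic carbon. Neither gives a size, and neither changes the group on the carbonyl carbon, so the expectation for this assay is weakly founded. The limit of compound 2 is > 21500 nM, and it leaves a readable change only towards lower numbers. The expected result is an at least 2.3-fold lower number from compound 2 to compound 4 (0.37 log units; beyond the scatter), towards lower numbers, though a further limit remains possible. For compound 4 the estimate is 9000 nM, with an expected range of 2500 nM to 21500 nM.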

Compound 4, half-maximal effective concentration: > 21500 nM
Compound 4: no number, only a limit (the forecaster's own chance of this, stated with the estimate: 35%); middle value at least 2.3-fold (0.37 log units) away from the limit.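

In this assay compound 4 gives > 21500 nM, which is a limit and not a number. No step can be read from compound 2 to compound 4: the limit of > 21500 nM in this assay, at which 4 of the 4 values shown sit. The compounds shown leave open at what concentration, if any, each would give a number in this assay.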